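Shortening the Amide Side Chain of Compound 2

This account rests on a few compounds, and the source may have more. Where it says the series, first, only, none or still open, it means among the compounds named here.

In a functional assay on BXPC-3 cells (Homo sapiens) for antiproliferative activity, read by MTT assay, with a stated time of 24 h (a lower number here means a stronger inhibitor, a higher number a weaker inhibitor), compound 1 (`CCn1c(C(=O)N[C@H](C)C(=O)OC)ccc1C(CC)(CC)c1ccc(OCS(=O)(=O)c2ccccc2)c(C)c1`) shows > 50000 nM as a limit of the assay. Among the measured compounds shown here, compound 2 (`CCn1c(C(=O)N[C@H](CO)C(C)C)ccc1C(CC)(CC)c1ccc(OCS(=O)(=O)c2ccccc2)c(C)c1`) gives 7720 nM as the only actual number so far. Compound 3 (`CCn1c(C(=O)NCCCO)ccc1C(CC)(CC)c1ccc(OCS(=O)(=O)c2ccccc2)c(C)c1`) carries 3-hydroxypropyl in place of 1-(hydroxymethyl)-2-methylpropyl on an amide-type nitrogen. For the measured compounds named here, the single measured step of an at least 6.4-fold lower number from compound 1 to compound 2 (0.81 log units; beyond the scatter) changed the group on that same kind of nitrogen, so a change there can matter. A modestly higher number is expected, the estimated step being a 1.8-fold higher number from compound 2 to compound 3 (0.26 log units; within the scatter) in this assay here. For compound 3 the estimate is 14000 nM with an expected range from 5000 nM to 40000 nM overall.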

Compound 3, half-maximal inhibitory concentration: 26600 nM
The estimate for compound 3 lay 1.9-fold (0.28 log units) below the measured number; the range from low to high includes it.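

With the hydrogen-bond donor and acceptor counts unchanged between 1-(hydroxymethyl)-2-methylpropyl and 3-hydroxypropyl, this assay still moves, with a 3.4-fold higher number from compound 2 to compound 3 (0.54 log units; beyond the scatter). This amide-type nitrogen therefore responds even when only the carbon chain and the defined stereocentre change. The step from 1-(methoxycarbonyl)ethyl is an at least 1.8-fold lower number from compound 1 to compound 3 (0.27 log units; that floor lies within the scatter), only a floor set by a limit of the assay: the limit of > 50000 nM in this assay, at which 1 of the 3 values shown sits.

The compounds shown leave open whether the branching or the stereocentre accounts for the step. They also leave open how a longer chain, an amine or a carboxylic acid on this nitrogen would read.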